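The source may report more compounds than this note shows. Statements on the series, on what has been measured and on what is new or still open speak of the compounds shown alone.

Measured in an ADME assay on MT4 cells (Homo sapiens) for cytotoxicity, read by MTT assay, with a stated time of 5 days; a lower number here means that less compound is tolerated, a higher number that more compound is tolerated:
- Compound 1 `Cc1cc(C)cc(Oc2cc(Nc3ccc(C#N)cc3)[nH]c(=O)c2I)c1`: 24000 nM
- Compound 2 `Cc1cc(C)c(Oc2cc(Nc3ccc([N+](=O)[O-])cc3)[nH]c(=O)c2)c(C)c1`: 26000 nM
- Compound 3 `Cc1cc(C)c(Oc2cc(Nc3ccc(C#N)cc3)[nH]c(=O)c2I)c(C)c1`: 34000 nM

In this assay, compound 3 at 34000 nM stands level with the other two compounds, since its gaps to both lie within the scatter. Compound 4 `Cc1cc(C)c(Oc2cc(Nc3ccc(C#N)cc3)[nH]c(=O)c2)c(C)c1` has hydrogen in place of iodo on an aromatic carbon. Among the measured compounds shown here, the only measured step, a 1.4-fold higher number from compound 1 to compound 3 (0.15 log units; within the scatter), swaps a different group, 3,5-dimethylphenyl for 2,4,6-trimethylphenyl, and keeps the iodo, so no measured step isolates this change. Compound 2 also has hydrogen at this place and gives 26000 nM, but it differs from compound 4 elsewhere as well. With so little to go on, a step beyond the scatter is not expected in this assay, and no direction can be favoured. The expected change is a 1.2-fold lower number from compound 3 to compound 4 (0.07 log units; within the scatter). For compound 4, the half-maximal cytotoxic concentration is estimated at 29000 nM, with an expected range from 13000 nM to 65000 nM.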

Compound 4, half-maximal cytotoxic concentration: 32000 nM
For compound 4 the middle estimate is 1.1-fold (0.04 log units) below the measured one; low and high end bracket the measured number.
By their numbers in this assay, from the lowest: compounds 1, 2, 4 and 3 (each within the scatter of the next).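

In this assay, among the compounds shown here, the step of a 1.1-fold lower number from compound 3 to compound 4 (0.03 log units; within the scatter) is the first to isolate this position, on an aromatic carbon two atoms from the ring nitrogen, and it shows that hydrogen in place of iodo leaves the number level on the 2,4,6-trimethylphenyl compounds. The second comparison, a 1.2-fold higher number from compound 2 to compound 4 (0.09 log units; within the scatter), shows the same for cyano in place of nitro, so neither of the two single changes moves the number beyond the scatter. Nothing available here offers a reason for either result.

The compounds shown carry only iodo or hydrogen at this position, so what an amine or a carboxylic acid there would do to the number stays open. Also open, going by these compounds, is whether hydrogen in place of iodo would leave the number level on the 3,5-dimethylphenyl compound 1.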